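A few compounds are considered here, and "the series" means these few. Any claim that something is new, unique, unknown or untested is made for them only; others in the source may bear on it.

Measured set:
- compound 1 `C#Cc1c(-c2ccccc2)[nH]c2ccccc12` — an assay on isolated protein for inhibition of Aromatase (Homo sapiens), read by fluorescence, using NADPH, with a stated time of 30 min, tested at 50 uM; on this read-out lower numbers stand for less inhibition and higher numbers for more inhibition at the one concentration tested (going by the name of the read-out): 88%
- compound 2 `Nc1cccc(-c2cc3ccccc3[nH]2)c1` — this assay: 26.7%
- compound 3 `COCn1c(-c2ccccc2)cc2ccccc21` — this assay: 20.2%

Compound 2 gives the second highest of the three numbers in this assay. Its gap to compound 3 is within the scatter, so the two cannot be ordered; compound 1 lies far above it, beyond the scatter, but differs from compound 2 in more than one place, so that gap gives no guide for a single change.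

Compound 4 `Clc1cccc(-c2cc3ccccc3[nH]2)c1` is not yet measured. It differs from compound 2 by chloro in place of amino on an aromatic carbon, on an aromatic carbon of a six-membered aromatic ring of carbon only, meta to a group of 9 heavy atoms.

Going by the values given here, no single-change step has been measured, so the size of the step is uncertain. A modest rise is expected, near the edge of the scatter, but a flat result is equally plausible. Compound 4 is estimated at 40% (range 15% to 70%), meaning an expected step of a number 13.3 percentage points higher from compound 2 to compound 4 (beyond the scatter).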

Compound 4, a percentage reported as inhibition, at one concentration (the size of the read-out at that concentration, not a potency): 24.2%
Estimate against measurement, compound 4: 15.8 percentage points above; low and high end bracket the measured number.
By their numbers in this assay, from the lowest: compounds 3, 4 and 2 (each within the scatter of the next); then compound 1.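

In this assay, going by these compounds alone, the first single-change step reads a number 2.5 percentage points lower from compound 2 to compound 4 (within the scatter), so this pair shows no resolved difference. At this place, meta to a group of 9 heavy atoms, chloro in place of amino goes from the hydrogen-bond donor and acceptor of amino to none, without a read-out change beyond the scatter. No supporting data bear on this result. From the compounds shown here alone, whether a hydroxyl, a nitrile or a carboxylic acid at this place would move the read-out remains open. So does the effect of chloro or amino elsewhere on this ring.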